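A few compounds are considered here, and "the series" means these few. Any claim that something is new, unique, unknown or untested is made for them only; others in the source may bear on it.

Within the data shown here, in a functional assay with Homo sapiens as the target, in the presence of a further agent that is not named here (a lower number here means a stronger inhibitor, a higher number a weaker inhibitor), compound 1 (`CC(C)[C@H](NC(=O)[C@H](CC(=O)O)NC(=O)CCCOc1ccc(C(=N)N)cc1)C(N)=O`) gives 670 nM, the second highest of the three numbers measured so far. Compound 2 (`CC(C)C(C)NC(=O)[C@H](CC(=O)O)NC(=O)CCCOc1ccc(C(=N)N)cc1`) gives 1400 nM, and compound 3 (`CC(C)[C@H](NC(=O)[C@H](CC(=O)O)NC(=O)CCCOc1ccc(C(=N)N)cc1)C(=O)N1CCS(=O)(=O)CC1`) gives 30 nM. The compound still to be measured, compound 4 (`CC(C)[C@H](NC(=O)[C@H](CC(=O)O)NC(=O)CCCOc1ccc(C(=N)N)cc1)C(=O)O`), keeps the core of compound 1 and alters a single group: hydroxy in place of amino on a carbonyl carbon. In words, this is hydroxy in place of amino on a carbonyl carbon, which turns carbamoyl into carboxy.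

Among the measured compounds shown here, no measured step makes this exact exchange, but two bear on it. Replacing 1-carbamoyl-2-methylpropyl with 1,2-dimethylpropyl on an amide-type nitrogen gave a 2.1-fold higher number from compound 1 to compound 2 (0.32 log units; beyond the scatter), a modest step. Replacing the same amino group with 1,1-dioxothiomorpholin-4-yl gave a 22-fold lower number from compound 1 to compound 3 (1.35 log units; beyond the scatter), a large step. These two show that the number responds to changes at this carbamoyl group, but the large step involves a much bigger group than hydroxy. A modest move towards a lower number is therefore expected, though with real uncertainty, and the estimate is a 2.2-fold lower number from compound 1 to compound 4 (0.35 log units; beyond the scatter). Compound 4 is expected at 300 nM, with an estimated range from 80 nM to 1100 nM.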

Compound 4, half-maximal inhibitory concentration: 100 nM
The estimate for compound 4 lay 3.0-fold (0.48 log units) above the measured number, within the range that was stated.
By their numbers in this assay, from the lowest: compound 3; then compound 4; then compound 1; then compound 2.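

In this assay, hydroxy in place of amino on this carbonyl carbon gives a 6.7-fold lower number from compound 1 to compound 4 (0.83 log units; beyond the scatter) and shows that exchanging one heavy atom for one heavy atom is enough to move the number, with no large group needed. Among these compounds, the 1-carboxy-2-methylpropyl group in place of 1,2-dimethylpropyl on the amide-type nitrogen gives a 14-fold lower number from compound 2 to compound 4 (1.15 log units; beyond the scatter) and is a far bigger move than the one the 1-carbamoyl-2-methylpropyl group made against that same 1,2-dimethylpropyl compound, so the end of this side chain matters more than compound 1 and compound 2 alone suggested. Hydroxy does not reach the level of the larger group, since hydroxy in place of 1,1-dioxothiomorpholin-4-yl gives a 3.3-fold higher number from compound 3 to compound 4 (0.52 log units; beyond the scatter) and the numbers on this carbonyl carbon fall in the order amino, hydroxy, 1,1-dioxothiomorpholin-4-yl.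

The compounds shown leave open where methoxy or morpholin-4-yl on the same carbonyl carbon would fall in that order. Nothing supplied here gives a measured reason for any of these steps, so why the number falls along this series remains unexplained.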